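This account rests on a few compounds, and the source may have more. Where it says the series, first, only, none or still open, it means among the compounds named here.

Among the compounds with values here, in a functional assay on MCF7 cells (Homo sapiens) for antiproliferative activity, read by MTT assay, with a stated time of 48 h (on this read-out lower numbers stand for stronger inhibition and higher numbers for weaker inhibition), none of the three compounds measured so far has given a number. Compound 1 `COc1ccc(-c2nc3cccc(-c4cc(OC)c(OC)c(OC)c4)c3o2)cc1OC` gives > 25000 nM as a limit. Compound 2 `COc1cc(-c2cccc3nc(-c4cccc(F)c4)oc23)cc(OC)c1OC` gives > 25000 nM as a limit too. Compound 3 `COc1cc(-c2cccc3nc(-c4cccc(O)c4)oc23)cc(OC)c1OC` likewise gives > 25000 nM as a limit. The measurements therefore offer only the limit of > 25000 nM in this assay, at which 3 of the 3 values shown sit, and no ranking. Compound 4 `COc1cc(-c2cccc3nc(-c4cccc(N)c4)oc23)cc(OC)c1OC` has amino in place of hydroxy on an aromatic carbon, and the change counts as amino in place of hydroxy on an aromatic carbon in full. Within the data shown here, the steps that bear on it are a step that the two limits leave unreadable from compound 2 to compound 3 and a step that the two limits leave unreadable from compound 1 to compound 3 and neither has a size to carry over. No step beyond the scatter is therefore expected in this assay and another limit is the likeliest report. The expected change is a number no higher from compound 3 to compound 4 (the limit leaves the size open) in size. The estimate for compound 4 is 25000 nM with an expected range from 10000 nM to 60000 nM overall.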

Compound 4, half-maximal inhibitory concentration: > 25000 nM
Compound 4: only a limit was reported; the forecaster's own chance of this, stated with the estimate: 75%; the middle value sits exactly at the limit.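

Compound 4 gives only a limit, as compounds 1, 2 and 3 do, so no step between any of them can be read in this assay: the limit of > 25000 nM in this assay, at which 4 of the 4 values shown sit.

The compounds shown leave open how these four would rank, and whether any group on the shared core can give an actual number in this assay.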